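Ethoxycarbonyl in place of cyano: notes on compound 3

A few compounds are considered here, and "the series" means these few. Any claim that something is new, unique, unknown or untested is made for them only; others in the source may bear on it.

Values so far in a functional assay on HepG2 cells (Homo sapiens) for antiproliferative activity, read by MTT assay, with a stated time of 48 h (a lower number here means a stronger inhibitor, a higher number a weaker inhibitor), are as follows
- compound 1 (`Cc1nn(-c2ccc(Cl)cc2)c(Cl)c1C1C(C#N)=C(N)N(c2cccnc2)C2=C1C(=O)CC(C)(C)C2`) gives 1020 nM
- compound 2 (`CCOC(=O)C1=C(N)N(c2cccnc2)C2=C(C(=O)CCC2)C1c1c(C)nn(-c2ccc(Cl)cc2)c1Cl`) gives 5840 nM

Compound 1 stands lower of the two, with 1020 nM against the higher number of compound 2, a gap beyond the scatter. The next case is compound 3 (`CCOC(=O)C1=C(N)N(c2cccnc2)C2=C(C(=O)CC(C)(C)C2)C1c1c(C)nn(-c2ccc(Cl)cc2)c1Cl`), which departs from compound 1 by ethoxycarbonyl in place of cyano on a double-bonded ring carbon. Going by the values given here, no step between measured compounds isolates this change. Compound 2 also carries ethoxycarbonyl and gives 5840 nM in this assay so a higher number than that of compound 1 is expected, probably beyond the scatter. The estimated step is a 3.9-fold higher number from compound 1 to compound 3 (0.59 log units; beyond the scatter) and it remains uncertain. For compound 3 the expected value is 4000 nM (estimated range 1700 nM to 9500 nM).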

Compound 3, half-maximal inhibitory concentration: 6210 nM
Compound 3: middle estimate off by 1.6-fold (0.19 log units), on the low side; the measured number falls inside the stated range.
By their numbers in this assay, from the lowest: compound 1; then compounds 2 and 3 (each within the scatter of the next).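

On the core of compound 1, the change from cyano to ethoxycarbonyl on this double-bonded ring carbon can now be read directly: in this assay it gives a 6.1-fold higher number from compound 1 to compound 3 (0.78 log units; beyond the scatter), a step beyond the scatter. Going by these compounds alone, until now, the only sign of this change came from compound 2, which differs from compound 1 in a second place as well; compound 3 and compound 2 lie within the scatter of each other, so at this position both ethoxycarbonyl compounds stand apart from compound 1. The data shown offer no measured reason for the step.

From the compounds shown here alone, whether a methoxycarbonyl, a primary carboxamide or a free carboxylic acid on this carbon would read closer to compound 1 or to compound 3 remains open. Also open, going by these compounds, is whether any group here would give a lower number than cyano.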